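Dropping a Chloro Group from a Propargylamine Inhibitor

This account rests on a few compounds, and the source may have more. Where it says the series, first, only, none or still open, it means among the compounds named here.

Compound 1 `C#CCNC1CCc2c(SCc3ccc4ccccc4c3)cccc21`: 69300 nM
Compound 2 `C#CCNC1CCc2c(SCc3cccc(Cl)c3)cccc21`: 1090 nM

Of the compounds shown here, two have been tested in an ADME assay on isolated protein for inhibition of Amine oxidase [flavin-containing] B (Homo sapiens); a higher number here means a weaker inhibitor, a lower number a stronger inhibitor. Compound 2 holds the lowest of the two numbers; its nearest neighbour, compound 1, gives a far higher number, well beyond the usual scatter. The next compound, compound 3 `C#CCNC1CCc2c(SCc3ccccc3)cccc21`, differs from compound 2 by one change: hydrogen in place of chloro on an aromatic carbon. Among the measured compounds shown here, no measured pair shows this change, so its size is unknown. Starting from the value of compound 2 in this assay, 1090 nM, a modest rise in the number is expected, a 2.8-fold higher number from compound 2 to compound 3 (0.44 log units; beyond the scatter). Compound 3 is therefore estimated at 3000 nM, within a range from 1000 nM to 10000 nM.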

Compound 3, half-maximal inhibitory concentration: "not active" (no number reported)
No number was reported for compound 3; the estimate stays without a comparison.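

Among the compounds shown here, compound 3 is reported as "not active" in this assay with no number, so no step from compound 2 can be read. Nothing available explains this result. From the compounds shown here alone, how much the chloro group contributes to inhibition stays open.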